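The source may report more compounds than this note shows. Statements on the series, on what has been measured and on what is new or still open speak of the compounds shown alone.

Measured compounds:
Compound 1, `O=C(CCCCCCNC(=O)C(O)C(F)(F)F)Nc1nccs1`: > 40000 nM
Compound 2, `O=C(CCCCCCNC(=O)C(O)(O)C(F)(F)F)Nc1nc2ccccc2o1`: 3450 nM
Compound 3, `O=C(CCCCCCNC(=O)C(O)(O)C(F)(F)F)Nc1nc2ccc(Br)cc2o1`: 12100 nM

In a functional assay on HCT-116 cells (Homo sapiens) for inhibition, read by colorimetric assay, with a stated time of 3 days (a lower number here means a stronger inhibitor, a higher number a weaker inhibitor), compound 2 gives 3450 nM, the lowest of the two numbers seen. Its nearest neighbour among them is compound 3, which gives 12100 nM. That separation is a 3.5-fold higher number from compound 2 to compound 3 (0.54 log units; beyond the scatter). For compound 1 the reading is a limit, (the limit of > 40000 nM in this assay, at which 1 of the 3 values shown sits), and not a number.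

Compound 4, `O=C(CCCCCCNC(=O)C(O)(O)C(F)(F)F)Nc1ccc(Cl)cc1`, has not yet been measured. It differs from compound 2 in one place: 4-chlorophenyl in place of 1,3-benzoxazol-2-yl on an amide-type nitrogen. Within the data shown here, no measured step makes this same exchange, so none bears on it directly. Among the measured compounds shown here, the only step seen, a 3.5-fold higher number from compound 2 to compound 3 (0.54 log units; beyond the scatter), concerns a substituent on the ring system that now leaves and shows that alterations in that part of the structure move the number by a modest amount. With the whole ring system exchanged, a step beyond the scatter is expected, more probably toward a higher number than a lower one. Compound 4 is therefore expected to give 8000 nM, between 2000 nM and 40000 nM. For compound 4 this means an expected step of a 2.3-fold higher number from compound 2 to compound 4 (0.37 log units; beyond the scatter).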

Compound 4, half-maximal inhibitory concentration: 4230 nM
The estimate for compound 4 lay 1.9-fold (0.28 log units) above the measured number; low and high end bracket the measured number.
By their numbers in this assay, from the lowest: compounds 2 and 4 (each within the scatter of the next); then compound 3. At a limit, above all of these: compound 1.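

In this assay, the exchange of 1,3-benzoxazol-2-yl for 4-chlorophenyl on the amide-type nitrogen gives a 1.2-fold higher number from compound 2 to compound 4 (0.09 log units; within the scatter) and thus no reading of a change. At this position, then, the five-membered aromatic ring with its 2 hetero atoms can leave, together with the 2 hydrogen-bond acceptors counted for the group, and a six-membered aromatic ring of carbon only with chlorine serves equally well in this cell assay. The earlier bromo step, a 3.5-fold higher number from compound 2 to compound 3 (0.54 log units; beyond the scatter) was beyond the scatter, so a substituent added to the ring system moved the number, whereas the exchange of the entire group did not.

The compounds shown leave open what the chlorine contributes, which an unsubstituted phenyl, or a phenyl carrying an amine or a carboxylic acid in its stead, would address. Nothing given here accounts for this result.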